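Arylpiperazine series: ring contraction at the chain terminus

This account rests on a few compounds, and the source may have more. Where it says the series, first, only, none or still open, it means among the compounds named here.

Measured so far in a functional assay on the whole organism for antagonist activity, with Rattus norvegicus as the target; a lower number here means that less compound is needed, a higher number that more compound is needed for the effect:
- compound 1, `C1=C(CCN2CCN(c3cccc4c3OCCO4)CC2)c2ccccc2CCC1`, 5.02 mg/kg
- compound 2, `c1ccc2c(c1)CC(CCCN1CCN(c3cccc4c3OCCO4)CC1)C2`, 0.47 mg/kg
- compound 3, `c1ccc2c(c1)CCCCC2CCN1CCN(c2cccc3c2OCCO3)CC1`, 4.26 mg/kg

Compound 2 stands lowest of the three numbers. Compound 3 is nearest to it, with a higher number that lies beyond the usual scatter, and compound 1 is furthest, also beyond the scatter. Going by the values given here, no pair of these measured compounds differs in one place only, so no single step can be read from them; the ranking alone shows that compound 2 needs the least compound for the effect.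

Compound 4, `c1ccc2c(c1)CC2CCCCN1CCN(c2cccc3c2OCCO3)CC1`, is the next candidate. It differs from compound 2 as follows: a group of 9 heavy atoms (9 carbon; one four-membered non-aromatic ring of carbon only, one six-membered aromatic ring of carbon only) in place of a group of 9 heavy atoms (9 carbon; one five-membered non-aromatic ring of carbon only, one six-membered aromatic ring of carbon only), on a saturated chain carbon, three bonds along the chain from an amine nitrogen in a ring.

Among the compounds with values here, with no comparable step available, the expectation rests on the rearrangement of the same atoms into a four-membered ring rather than a five-membered one, which also alters how the aromatic ring is held relative to the chain. A moderate rise in the number is expected, around the edge of the scatter or somewhat beyond it, with considerable uncertainty. The step from compound 2 to compound 4 is estimated as a 2.1-fold higher number from compound 2 to compound 4 (0.33 log units; beyond the scatter). Compound 4 is expected to give 1 mg/kg in this assay, with a range from 0.35 mg/kg to 3 mg/kg.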

Compound 4, dose for 50% inhibition: 1.43 mg/kg
Beside the measured number, compound 4's estimate is 1.4-fold (0.16 log units) below it; the measured number falls inside the stated range.
By their numbers in this assay, from the lowest: compound 2; then compound 4; then compounds 3 and 1 (each within the scatter of the next).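

In this assay the series gains its first readable step, a 3.0-fold higher number from compound 2 to compound 4 (0.48 log units; beyond the scatter), on exchanging the 2,3-dihydro-1H-inden-2-yl group for a group with a four-membered non-aromatic ring of carbon only, on a saturated chain carbon, three bonds along the chain from an amine nitrogen in a ring. The two groups have the same heavy atom count, no hydrogen-bond donors or acceptors and no net charge, yet the number still moves beyond the scatter, showing that at this position the way the same atoms are joined is enough to change the dose needed. No measurement at hand bears on the reason for this step.

This single step leaves open how a plain phenyl or cyclohexyl group would compare at this position. On these data alone, the effect of a hydroxyl group on the four-membered ring also remains open.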